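Swapping the Long Chain of Compound 3 for an Ester

The source may hold more compounds than are shown below. What is called first, only, known or untested is meant among the compounds shown, and "the series" means these compounds.

Compound 1 `O=C(O[C@H]1C[C@H](n2cc(F)c(=O)[nH]c2=O)O[C@@H]1COP(=O)(O)Oc1cccnc1)c1ccccc1`: 1300 nM
Compound 2 `C[n+]1cccc(OP(=O)([O-])OC[C@H]2O[C@@H](n3cc(F)c(=O)[nH]c3=O)C[C@@H]2OC(=O)c2ccccc2)c1`: 3480 nM
Compound 3 `CCCCCCCCCC[n+]1cccc(OP(=O)([O-])OC[C@H]2O[C@@H](n3cc(F)c(=O)[nH]c3=O)C[C@@H]2OC(=O)c2ccccc2)c1`: 400 nM

All three were tested in a functional assay on T98G cells (Homo sapiens) for cytotoxicity, read by MTT assay, with a stated time of 48 h; a lower number here means a stronger inhibitor, a higher number a weaker inhibitor. Compound 3 stands lowest of the three, with compound 1 nearer to it and compound 2 furthest away. Compound 4 `CCOC(=O)C[n+]1cccc(OP(=O)([O-])OC[C@H]2O[C@@H](n3cc(F)c(=O)[nH]c3=O)C[C@@H]2OC(=O)c2ccccc2)c1` differs from compound 3 by ethoxycarbonyl in place of nonyl on a saturated chain carbon bound to an aromatic nitrogen. Within the data shown here, the one measured step that bears on this is an 8.7-fold lower number from compound 2 to compound 3 (0.94 log units; beyond the scatter), in which the nonyl was added. Taking the nonyl away again in compound 4 is expected to undo much of that drop, and the incoming ethoxycarbonyl has no measured precedent here. A rise a 6.3-fold higher number from compound 3 to compound 4 (0.80 log units; beyond the scatter) is therefore expected, landing compound 4 nearer to compound 2. The estimate for compound 4 is 2500 nM, with a range from 1000 nM to 6000 nM.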

Compound 4, half-maximal inhibitory concentration: 1600 nM
Compound 4: middle estimate off by 1.6-fold (0.19 log units), on the high side, and the stated range covers the measured number.
By their numbers in this assay, from the lowest: compound 3; then compounds 1 and 4 (each within the scatter of the next); then compound 2.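

In this assay, ethoxycarbonyl in place of nonyl on a saturated chain carbon bound to an aromatic nitrogen gives a 4.0-fold higher number from compound 3 to compound 4 (0.60 log units; beyond the scatter), so the ester does not keep the full gain seen with the long chain. Ethoxycarbonyl in place of hydrogen at that same place still gives a 2.2-fold lower number from compound 2 to compound 4 (0.34 log units; beyond the scatter), which shows that nonyl is not the only group there that lowers the number. No available evidence explains the difference between these groups. The compounds shown leave open how a shorter chain such as butyl, or a carboxylic acid in place of ethoxycarbonyl, would fare at this place.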